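The source may report more compounds than this note shows. Statements on the series, on what has been measured and on what is new or still open speak of the compounds shown alone.

Working notes on the series. Compound 1 `CC(C)c1ccc2c(CCC/C=N/N=C(\S)Nc3ccccc3)cc(C(=O)O)c-2cc1` gives 590000 nM in a functional assay on thoracic aorta for antagonist activity at thromboxane A2 receptor (Rattus norvegicus); on this read-out lower numbers stand for stronger inhibition and higher numbers for weaker inhibition; compound 2 `CC(C)c1ccc2c(CCCCS(=O)(=O)Nc3ccccc3)cc(C(=O)O)c-2cc1` gives 8700 nM; compound 3 `CC(C)c1ccc2c(CCCCS(=O)(=O)Nc3ccc(Cl)cc3)cc(C(=O)O)c-2cc1` gives 2600 nM. Compound 2 thus stands second highest of the three numbers, nearest compound 3 and far from compound 1. For the measured compounds named here, the only single-site step measured, a 3.3-fold lower number from compound 2 to compound 3 (0.52 log units; beyond the scatter), concerns the anilide ring and not the carboxy group. Compound 4 `CC(C)c1ccc2c(CCCCS(=O)(=O)Nc3ccccc3)cc(S(=O)(=O)O)c-2cc1` differs from compound 2 by sulfo in place of carboxy on an aromatic carbon. Going by the values given here, no measured step bears on this exchange, so its size in this assay cannot be read from the series; the expectation is a change not clearly beyond the scatter, in either direction. Compound 4 is expected at 12000 nM, range 3000 nM to 50000 nM, an estimated step of a 1.4-fold higher number from compound 2 to compound 4 (0.14 log units; within the scatter).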

Compound 4, half-maximal inhibitory concentration: 1500 nM
For compound 4 the middle estimate is 8.0-fold (0.90 log units) above the measured one, outside the stated range (below it).
By their numbers in this assay, from the lowest: compounds 4 and 3 (each within the scatter of the next); then compound 2; then compound 1.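

For the compounds shown here, with sulfo in place of carboxy on the aromatic carbon, this assay shows a 5.8-fold lower number from compound 2 to compound 4 (0.76 log units; beyond the scatter), the first measured evidence that this position, and not only the anilide ring, can shift the number. Within this pair, the carboxy group is not required for inhibition, and the exchange gives a lower number. Nothing on hand accounts for this change. The compounds shown leave open whether a phosphonic acid or a tetrazole on the same aromatic carbon would give a similar number, and whether chloro on the anilide ring would lower the number again with sulfo present.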